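The compounds below may be only part of what the source reports. "The series", "measured", "known", "first", "only" and "open" are said of these compounds alone.

Compound 1, `C/C(=C\c1cc(-c2ccc(C)cc2)cs1)C(N)=O`, was tested in an ADME assay on NIH3T3 cells (Mus musculus) for cytotoxicity, read by CCK-8 assay, with a stated time of 24 h; on this read-out higher numbers stand for weaker inhibition and lower numbers for stronger inhibition. In this assay compound 1 gives > 50000 nM, which is a limit of the assay rather than a number. Going by the values given here, compound 2, `C/C(=C\c1cccc(-c2ccc(C)cc2)c1)C(N)=O`, is the only other compound with a result here. In this assay compound 2 gives > 50000 nM, again a limit and not a number. Both results therefore sit at the same point: the limit of > 50000 nM in this assay, at which 2 of the 2 values shown sit. Compound 1 thus stands at that limit, and no order between compound 1 and compound 2 can be drawn from the two values.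

Compound 3, `C/C(=C\c1cc(-c2ccc(C(F)(F)F)cc2)cs1)C(N)=O`, has not yet been measured. It differs from compound 1 in one place: trifluoromethyl in place of methyl on an aromatic carbon. Among the compounds with values here, no step between measured compounds is available, so nothing measured speaks to the size of this change.

Compound 3 is expected to remain at or near the same limit, with an expected step of a number no higher from compound 1 to compound 3 (the limit leaves the size open) of no size beyond the scatter. The estimate for compound 3 is 50000 nM, with a range from 20000 nM to 120000 nM.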

Compound 3, half-maximal inhibitory concentration: > 50000 nM
Compound 3 gave a limit, no number; the forecaster's own chance of this, stated with the estimate: 85%; the middle value lies on the limit itself.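

In this assay compound 3 gives > 50000 nM, which is a limit and not a number. Going by these compounds alone, compound 1 also stands at a limit, so no step from compound 1 to compound 3 can be read, and the three compounds share one position: the limit of > 50000 nM in this assay, at which 3 of the 3 values shown sit. The compounds shown leave open how they rank in this assay and what concentration, if any, would produce half-maximal inhibition.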